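The compounds below may be only part of what the source reports. "The series", "measured", "known", "first", "only" and "open" are said of these compounds alone.

Compound 1 `COc1cccc(/C=C/C(=O)c2sc(Nc3cccc(C)c3)nc2C)c1` is the starting point of this comparison. In a functional assay on PC-3 cells (Homo sapiens) for cytotoxicity, read by MTT assay (a lower number here means a stronger inhibitor, a higher number a weaker inhibitor), compound 1 gives > 25000 nM, which is a limit of the assay and not a measured number. Compound 2 `Cc1cccc(Nc2nc(C)c(C(=O)/C=C/c3ccccc3)s2)c1` carries hydrogen in place of the methoxy group on the aromatic ring of the chain and gives 11700 nM, so the step of an at least 2.1-fold lower number from compound 1 to compound 2 (0.32 log units; beyond the scatter) runs toward a stronger inhibitor. Compound 3 `Cc1cccc(Nc2nc(C)c(C(=O)/C=C/c3ccc(Cl)cc3)s2)c1` carries chloro in place of that hydrogen. Compound 3 gives > 25000 nM, again a limit of the assay. The step of an at least 2.1-fold higher number from compound 2 to compound 3 (0.32 log units; beyond the scatter) runs back toward a weaker inhibitor, while a step that the two limits leave unreadable from compound 1 to compound 3. Taken together, the limit of > 25000 nM in this assay, at which 2 of the 3 values shown sit, marks how close this series sits to the edge of what the assay can resolve.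

Compound 4 `COc1cccc(/C=C/C(=O)c2sc(Nc3cccc(Cl)c3)nc2C)c1` differs from compound 1 by chloro in place of methyl on an aromatic carbon. None of the three measured steps touches that part of the molecule; all of them sit on the ring at the end of the chain. Within the data shown here, they therefore tell nothing direct about this change, only that small changes on a ring of this series move the number by modest amounts around the limit. Compound 4 is expected to stay near the limit of compound 1, with an estimated step that the limit leaves unreadable from compound 1 to compound 4 that is not beyond the scatter. The estimate for compound 4 is 30000 nM, in a range from 9000 nM to 90000 nM.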

Compound 4, half-maximal inhibitory concentration: > 25000 nM
Compound 4 gave a limit, no number (the forecaster's own chance of this, stated with the estimate: 65%); the middle value is on the limit's open side.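

In this assay compound 4 gives > 25000 nM as a limit of the assay and not a number. Among these compounds, compound 1 also stands at a limit, so no step between compound 1 and compound 4 can be read. The comparison stops at this edge: the limit of > 25000 nM in this assay, at which 3 of the 4 values shown sit. The compounds shown leave open whether chloro in place of methyl changes the number at all.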